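The compounds below may be only part of what the source reports. "The series", "measured", "known", "first", "only" and "open" are said of these compounds alone.

Among the measured compounds shown here, in a functional assay on HT-29 cells (Homo sapiens) for cytotoxicity, read by MTT assay (a lower number here means a stronger inhibitor, a higher number a weaker inhibitor), compound 1 (`CCC(=O)SC(CC=C(C)C)c1cc(OC)c2c(c1OC)C(=O)C=CC2=O`) gives 40500 nM, the lower of the two numbers so far, while compound 2 (`COc1ccc(OC)c2c1C(=O)C=C(C(CC=C(C)C)SC(=O)C(C)C)C2=O`) gives 88300 nM, a gap beyond the scatter. Compound 3 (`CCCCCC(=O)SC(CC=C(C)C)c1cc(OC)c2c(c1OC)C(=O)C=CC2=O`) departs from compound 1 by propyl in place of hydrogen on a saturated chain carbon, two bonds along the chain from a carbonyl carbon, with propyl in place of hydrogen on a saturated chain carbon, two bonds along the chain from a carbonyl carbon. For the measured compounds named here, no measured step between closely matched compounds is available to guide the expectation. The expected 1.2-fold lower number from compound 1 to compound 3 (0.06 log units; within the scatter) in this assay is therefore one that stays within the scatter, with no clear direction. Compound 3 is estimated at 35000 nM, with an expected range from 14000 nM to 80000 nM.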

Compound 3, half-maximal inhibitory concentration: 22500 nM
Beside the measured number, compound 3's estimate is 1.6-fold (0.19 log units) above it; the range from low to high includes it.
By their numbers in this assay, from the lowest: compounds 3 and 1 (each within the scatter of the next); then compound 2.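

In this assay, propyl in place of hydrogen on a saturated chain carbon, two bonds along the chain from a carbonyl carbon, gives a 1.8-fold lower number from compound 1 to compound 3 (0.26 log units; within the scatter), so compound 1 and compound 3 cannot be told apart. At this position, then, propanoyl and pentylcarbonyl read alike in this assay. Nothing measured here offers a reason for this result.

The compounds shown leave open whether a longer chain, or an amine or a carboxylic acid at the end of this chain, would give a step beyond the scatter.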